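Swapping a Benzyl Arm for a Diethylamino Chain

The compounds below may be only part of what the source reports. "The series", "measured", "known", "first", "only" and "open" are said of these compounds alone.

Compound 1 `COC(=O)c1c([N+](=O)[O-])noc1-c1ccc([N+](=O)[O-])cc1`: "not determined" (no result reported)
Compound 2 `COC(=O)c1c(NCc2ccc(C(C)(C)C)cc2)noc1-c1ccc([N+](=O)[O-])cc1`: 81400 nM

For the measured compounds named here, in an ADME assay on J774.A1 cells (Mus musculus) for cytotoxicity, read by MTT assay, with a stated time of 48 h (on this read-out higher numbers stand for lower toxicity in this test and lower numbers for higher toxicity in this test), compound 2 gives 81400 nM, the only number in this small set; compound 1 has no reported result, so compound 2 stands alone. Compound 3 `CCN(CC)CCNc1noc(-c2ccc([N+](=O)[O-])cc2)c1C(=O)OC` differs from compound 2 in one place: (diethylamino)methyl in place of 4-(tert-butyl)phenyl on a saturated chain carbon bound to a nitrogen on an aromatic ring. Going by the values given here, no measured pair shows what such a change does here, so the expectation rests on compound 2 alone. The expected step is a 1.5-fold higher number from compound 2 to compound 3 (0.17 log units; within the scatter), a modest move toward lower toxicity, barely beyond the scatter. Compound 3 is expected to give 120000 nM, within 40000 nM to 300000 nM.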

Compound 3, half-maximal cytotoxic concentration: 69300 nM
For compound 3 the middle estimate is 1.7-fold (0.24 log units) above the measured one, within the range that was stated.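

In this assay, putting (diethylamino)methyl in place of 4-(tert-butyl)phenyl gives a 1.2-fold lower number from compound 2 to compound 3 (0.07 log units; within the scatter) so the two compounds cannot be told apart in this test. At this place on the chain, then, an aromatic ring can give way to an open chain holding a nitrogen without a readable change in the number. Nothing measured here offers a reason for this. As far as these compounds go, whether a carboxylic acid or a morpholine at the same place would shift the number beyond the scatter remains open.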